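A Methyl on the Aromatic Ring of Compound 1

A few compounds are considered here, and "the series" means these few. Any claim that something is new, unique, unknown or untested is made for them only; others in the source may bear on it.

Compound 1, `CC(C)(C)OC(=O)/C=C1/C(=O)Nc2ccccc21`, is the reference point. In a functional assay on SW480 cells (Homo sapiens) for inhibition, read by CCK-8 assay, with a stated time of 72 h, tested at 20 uM (a lower number here means less inhibition of growth, a higher number more inhibition of growth at the concentration tested), compound 1 gives 78.1%. Within the data shown here, its only measured companion is compound 2, `CC(C)(C)OC(=O)/C=C1/C(=O)N(Cc2ccccc2)c2ccccc21`, which in this assay gives 78.4%; the change of a number 0.3 percentage points higher from compound 1 to compound 2 (within the scatter) leaves the two numbers within the scatter of each other, so neither compound can be set apart from the other.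

Compound 3, `Cc1ccc2c(c1)/C(=C\C(=O)OC(C)(C)C)C(=O)N2`, differs from compound 1 by methyl in place of hydrogen on an aromatic carbon. Among the measured compounds shown here, no measured step touches this ring carbon; the one step available, from a hydrogen to a benzyl on the ring nitrogen, is at a different place and produced no shift beyond the scatter. On that slim basis the expectation is a step of a number 2.1 percentage points lower from compound 1 to compound 3 (within the scatter), that is, none beyond the scatter. Compound 3 is therefore estimated at 76% in this assay, with a range from 62% to 86%.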

Compound 3, percent growth inhibition at one concentration: 79%
Compound 3: the middle estimate sits 3 percentage points below what was measured; the measured number falls inside the stated range.
By their numbers in this assay, from the lowest: compounds 1, 2 and 3 (each within the scatter of the next).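

In this assay, methyl in place of hydrogen on this aromatic carbon gives a number 0.9 percentage points higher from compound 1 to compound 3 (within the scatter). Among these compounds, the earlier step changed only the ring nitrogen, so this is the first reading for a change on the carbon part of the shared core, and at this carbon methyl cannot be told apart from hydrogen at the single concentration tested. Nothing available explains why the number stays within the scatter.

As far as these compounds go, it remains open whether a different group on this same carbon, such as an amine, a carboxylic acid or a longer chain, would move the number beyond the scatter. The compounds shown also leave open whether methyl would behave the same way on the other carbons of this aromatic ring.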